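The source may hold more compounds than are shown below. What is called first, only, known or untested is meant among the compounds shown, and "the series" means these compounds.

Measured compounds:
compound 1, `O=C1NCc2c1c1c(c3c2c2ccccc2n3CCO)CCc2cc(OCc3ccccn3)ccc2-1`: 30%
compound 2, `O=C1NCc2c1c1c(c3c2c2ccccc2n3CCO)CCc2cc(OCCOCc3ccccc3)ccc2-1`: 0%
compound 3, `O=C1NCc2c1c1c(c3c2c2ccccc2n3CCO)CCc2cc(OC3CCCC3)ccc2-1`: 32%

All three share one core and differ only in the group on an oxygen on an aromatic ring. In an assay on isolated protein for inhibition of mitogen-activated protein kinase kinase kinase 11 (Homo sapiens), tested at 1 uM (on this read-out lower numbers stand for less inhibition and higher numbers for more inhibition at the one concentration tested (going by the name of the read-out)), compound 3 gives the highest of the three numbers, but its lead over compound 1 is small, a number 2 percentage points higher from compound 1 to compound 3 (within the scatter), whereas compound 2 lies far beneath it, a number 32 percentage points higher from compound 2 to compound 3 (beyond the scatter).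

Compound 4, `N#CCCCOc1ccc2c(c1)CCc1c-2c2c(c3c4ccccc4n(CCO)c13)CNC2=O`, has not yet been measured. Its difference from compound 3 is 3-cyanopropyl in place of cyclopentyl on an oxygen on an aromatic ring: a five-membered non-aromatic ring of carbon only is replaced by a chain of the same heavy-atom count that carries no ring and one hydrogen-bond acceptor.

Within the data shown here, no measured step involves a 3-cyanopropyl group, so guidance is indirect. Among the measured compounds shown here, the one step in which a group on that oxygen was exchanged for a longer chain without a ring, a number 30 percentage points lower from compound 1 to compound 2 (beyond the scatter), lowered the number beyond the scatter, and a number 32 percentage points higher from compound 2 to compound 3 (beyond the scatter) shows the reverse. A decrease in this assay is therefore expected for compound 4, estimated as a number 17 percentage points lower from compound 3 to compound 4 (beyond the scatter). Compound 4 is expected to give about 15%, with a likely range from 0% to 35%.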

Compound 4, a percentage reported as inhibition, at one concentration (the size of the read-out at that concentration, not a potency): 46%
Beside the measured number, compound 4's estimate is 31 percentage points below it, and the stated range ends below it.
By their numbers in this assay, from the lowest: compound 2; then compounds 1 and 3 (each within the scatter of the next); then compound 4.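

In this assay the number is higher with the open 3-cyanopropyl chain on this oxygen than with the cyclopentyl ring, with a number 14 percentage points higher from compound 3 to compound 4 (beyond the scatter) when it replaces that ring, and it also gives a number 16 percentage points higher from compound 1 to compound 4 (beyond the scatter) and a number 46 percentage points higher from compound 2 to compound 4 (beyond the scatter) against the other two groups. A chain on this oxygen therefore does not lower the number as such, so the low value of compound 2 cannot be read as a penalty for any chain. Nothing available here explains why the nitrile-bearing chain gives the highest number.

The compounds shown leave open whether the nitrile or the chain itself accounts for the rise, a question that a plain butyl chain, a longer nitrile-bearing chain or an amine at the chain end could address. They also leave open how these readings at one concentration would translate into potency.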